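The source may report more compounds than this note shows. Statements on the series, on what has been measured and on what is new or still open speak of the compounds shown alone.

In a functional assay on HepG2 cells (Homo sapiens) for antiproliferative activity, read by MTT assay, with a stated time of 48 h (on this read-out lower numbers stand for stronger inhibition of growth and higher numbers for weaker inhibition of growth), the series around a shared core is examined with one structural change repeated in two settings. Compound 1, `CCCOC(=O)N1N=C(c2ccc(OC)cc2)CC1c1cc(OC)c(OC)c(OC)c1`, is the starting point. In this assay compound 1 gives > 10000 nM, which is a limit of the assay and not a number. Compound 2, `COc1ccc(C2=NN(C(=O)OCc3ccccc3)C(c3cc(OC)c(OC)c(OC)c3)C2)cc1`, differs from compound 1 by phenyl in place of ethyl on a saturated chain carbon bound to an oxygen next to a carbonyl group. In this assay compound 2 gives > 10000 nM, again a limit. The step that the two limits leave unreadable from compound 1 to compound 2 therefore cannot be sized. Compound 3, `CCCOC(=O)N1N=C(c2cccc(O)c2)CC1c1cc(OC)c(OC)c(OC)c1`, carries a different core than compound 1; the cores differ by 3-hydroxyphenyl in place of 4-methoxyphenyl on a carbon with a double bond to nitrogen. In this assay compound 3 gives > 10000 nM, once more a limit. The step that the two limits leave unreadable from compound 1 to compound 3 is likewise unreadable. All three values stand at the limit of > 10000 nM in this assay, at which 3 of the 3 values shown sit.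

Compound 4, `COc1cc(C2CC(c3cccc(O)c3)=NN2C(=O)OCc2ccccc2)cc(OC)c1OC`, is not yet measured. It differs from compound 3 by phenyl in place of ethyl on a saturated chain carbon bound to an oxygen next to a carbonyl group, the same change that separates compound 2 from compound 1, set on the same place in both pairs. Since the earlier pair left its step unreadable, the new step is expected to be a step that the limit leaves unreadable from compound 3 to compound 4, resting on compound 1 and compound 2 both sitting at the limit of > 10000 nM in this assay, at which 3 of the 3 values shown sit. Compound 4 is therefore estimated at 20000 nM in this assay, with a range from 10000 nM to 60000 nM, and it is expected most likely to return only a limit, because the limit of > 10000 nM in this assay, at which 3 of the 3 values shown sit, is where every measured compound of this set sits.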

Compound 4, concentration for 50% growth inhibition: > 10000 nM
Compound 4 gave a limit, no number (the forecaster's own chance of this, stated with the estimate: 85%); the middle value does not contradict the limit.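

In this assay compound 4 gives > 10000 nM, which is a limit of the assay and not a number. The steps from compound 3 and from compound 2 to compound 4 cannot be read, because both ends of each step are limits: the limit of > 10000 nM in this assay, at which 4 of the 4 values shown sit.

The compounds shown leave open whether phenyl in place of ethyl, or 3-hydroxyphenyl in place of 4-methoxyphenyl, changes growth inhibition at all.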